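Cyano in place of the sulfur group on the shared core

The source may report more compounds than this note shows. Statements on the series, on what has been measured and on what is new or still open speak of the compounds shown alone.

Compound 1 `COCCOCn1cc(C#N)c2c(N)ncnc21` gives > 100000 nM (a limit)
Compound 2 `CCOCn1cc(C(=N)S)c2c(N)ncnc21` gives 60000 nM
Compound 3 `CCOCn1cc(C#N)c2c(N)ncnc21` is not yet measured

Within the data shown here, compound 2 gives 60000 nM in a functional assay on KB cells (Homo sapiens) for inhibition (a higher number here means a weaker inhibitor, a lower number a stronger inhibitor), as the only actual number so far. Compound 1 stands at > 100000 nM in this assay as a limit of the assay, not a number.

Compound 3 keeps the ethoxymethyl group and takes a cyano on the aromatic carbon of the five-membered aromatic ring, in place of the group of 3 heavy atoms in compound 2 (a group of 2 heavy atoms (1 carbon, 1 nitrogen; no ring) in place of a group of 3 heavy atoms (1 carbon, 1 nitrogen, 1 sulfur; no ring), on an aromatic carbon). No measured step sizes this change. Among the measured compounds shown here, the only hint is that compound 1, which also bears a cyano, sits at the limit of > 100000 nM in this assay, at which 1 of the 2 values shown sits, without a number. Expected is a 1.7-fold higher number from compound 2 to compound 3 (0.22 log units; within the scatter) toward weaker inhibition, small and not clearly beyond the scatter. For compound 3 the estimate is 100000 nM, with an expected range from 35000 nM to 250000 nM and a report at the limit quite possible.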

Compound 3, half-maximal inhibitory concentration: > 100000 nM
Compound 3: only a limit was reported; the forecaster's own chance of this, stated with the estimate: 55%; the middle value lies on the limit itself.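

Compound 3 gives > 100000 nM in this assay, a limit of the assay and not a number. On this aromatic carbon, cyano in place of the group of 3 heavy atoms gives an at least 1.6-fold higher number from compound 2 to compound 3 (0.22 log units; that floor lies within the scatter), so the change is bounded on one side only and is not shown to exceed the scatter. The step from compound 1 to compound 3 cannot be read, because both compounds sit at the same limit, and the hydrogen in place of methoxy on the chain gets no size: the limit of > 100000 nM in this assay, at which 2 of the 3 values shown sit.

As far as these compounds go, it remains open how a carboxamide or an aminomethyl group on this aromatic carbon would read in this assay. Also open, from the compounds shown here alone, is whether a longer chain or a benzyl group in place of the ethoxymethyl group would bring the cyano compounds to a measurable number.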